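Fluoro in place of hydrogen, read against limits only

This account rests on a few compounds, and the source may have more. Where it says the series, first, only, none or still open, it means among the compounds named here.

In a physicochemical assay for solubility, using the shake flask method, measured as kinetic solubility, with a stated time of 20 h, at pH 2 (a lower number here means a less soluble compound, a higher number a more soluble compound), compound 2 `Fc1ccc(Nc2cc3[nH]c(-c4cccc(C(F)(F)F)c4)nc3cn2)nc1` gives < 5000 nM as a limit and not a number. Compound 1 `COc1ccc(Nc2cc3[nH]c(-c4cccc(C(F)(F)F)c4)nc3cn2)nc1` gives < 5000 nM in this assay as a limit too. Compound 3 `Fc1cnc(Nc2cc3[nH]c(-c4cccc(C(F)(F)F)c4)nc3cn2)c(F)c1` gives < 5000 nM in this assay as a limit as well. All three share one reading, the limit of < 5000 nM in this assay, at which 3 of the 3 values shown sit, and so compound 2 cannot be ranked against the others.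

Compound 4 `Fc1ccc(Nc2cc3[nH]c(-c4ccc(F)c(C(F)(F)F)c4)nc3cn2)nc1` carries a single change, fluoro in place of hydrogen on an aromatic carbon that is, fluoro in place of hydrogen on an aromatic carbon, ortho to a trifluoromethyl group.

Among the measured compounds shown here, the closest precedent, also fluoro in place of hydrogen on an aromatic carbon, is a step that the two limits leave unreadable from compound 2 to compound 3 and the same holds for a step that the two limits leave unreadable from compound 1 to compound 2 and for a step that the two limits leave unreadable from compound 1 to compound 3 in this small set. No size can be carried over, so no step beyond the scatter is expected in this assay in either direction. The expected step is a step that the limit leaves unreadable from compound 2 to compound 4 on this reading. For compound 4 the estimate is 2500 nM with an expected range from 800 nM to 5000 nM and a limit is the likeliest report.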

Compound 4, solubility: 13000 nM
Estimate against measurement, compound 4: 5.2-fold (0.72 log units) below; the measured number lies above the stated range.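

In this assay, fluoro in place of hydrogen on an aromatic carbon, ortho to a trifluoromethyl group, gives an at least 2.6-fold higher number from compound 2 to compound 4 (0.41 log units; beyond the scatter). Among the compounds shown here, this is the first size the set offers for the change and the first on this ring, since the steps among compound 1, compound 2 and compound 3 cannot be read. Compound 4 alone reads as a number and not as a limit: the limit of < 5000 nM in this assay, at which 3 of the 4 values shown sit.

Going by these compounds, the upper size of the step stays open, as compound 2 has only a limit and a single pair fixes only a lower bound. On these data alone, whether this carbon answers to fluoro alone also stays open, for a chloro, a nitrile or an amine at the same place might give a step of another size or direction.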